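Swapping methyl for fluoro on the outer ring

The source may report more compounds than this note shows. Statements on the series, on what has been measured and on what is new or still open speak of the compounds shown alone.

Within the data shown here, compound 1, `Cc1ccc(Oc2ccc(/C=N/NC(=O)CSc3nc4ccccc4s3)cc2)cc1`, gives 5.7 in a physicochemical assay for lipophilicity, in phosphate buffer, measured as octanol-water partition, with a stated time of 24 h (a lower number here means a more polar compound, a higher number a more lipophilic compound), and stands highest of the three numbers known so far. Compound 3, `Cc1ccc(Oc2ccc(/C=N/Nc3nc4ccccc4s3)cc2)cc1`, gives 5.4, which lies within the scatter of compound 1, while compound 2, `O=[N+]([O-])c1ccc(Oc2ccc(/C=N/Nc3nc4ccccc4s3)cc2)cc1`, gives 5.1, beyond the scatter of compound 1. Among the measured compounds shown here, the only single-point step among the measured compounds is a number 0.30 log units higher from compound 2 to compound 3 (within the scatter). Compound 4, `O=C(CSc1nc2ccccc2s1)N/N=C/c1ccc(Oc2ccc(F)cc2)cc1`, differs from compound 1 by fluoro in place of methyl on an aromatic carbon. For the measured compounds named here, no measured step trades a methyl for a fluoro, so the measured steps bear on it only loosely, and all of them were small. A modest decrease is expected, a number 0.30 log units lower from compound 1 to compound 4 (within the scatter). Compound 4 is therefore estimated at 5.4, ranging from 5 to 5.8 in this assay.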

Compound 4, partition coefficient: 5.5
For compound 4 the middle estimate is 0.10 log units below the measured one; the measured number falls inside the stated range.
By their numbers in this assay, from the lowest: compounds 2, 3, 4 and 1 (each within the scatter of the next, the first and the last beyond it).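

In this assay, fluoro in place of methyl on this aromatic carbon, para to a large group, gives a number 0.20 log units lower from compound 1 to compound 4 (within the scatter), so the read-out does not separate these two groups here. Among these compounds, no earlier pair covered this swap at this position in the core of compound 1. Nothing available explains the result.

Still open, as far as these compounds go, is how an amine, a carboxylic acid or a longer alkyl chain at this position would read. Also open, from the compounds shown here alone, is whether fluoro would read the same on the core of compound 3.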